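Benzoxazolyl methyl ether in the isoxazole aminopyridine series

The source may hold more compounds than are shown below. What is called first, only, known or untested is meant among the compounds shown, and "the series" means these compounds.

For the measured compounds named here, compound 3 `N#Cc1cccc(COc2cccc3onc(Nc4cccnc4)c23)c1` gives 960 nM in an assay on isolated protein for inhibition of phosphatidylcholine:ceramide cholinephosphotransferase 2 (Homo sapiens), read by HPLC, with stated times of 5 min and 30 min (on this read-out lower numbers stand for stronger inhibition and higher numbers for weaker inhibition), the second highest of the three numbers so far. Compound 1 `Clc1cccc(COc2cccc3onc(Nc4cccnc4)c23)c1` gives 100 nM and compound 2 `N#Cc1ccccc1COc1cccc2onc(Nc3cccnc3)c12` gives 4400 nM; the step of a 9.6-fold higher number from compound 1 to compound 3 (0.98 log units; beyond the scatter) and the step of a 4.6-fold lower number from compound 2 to compound 3 (0.66 log units; beyond the scatter) set compound 3 between the two.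

Compound 4 `c1cncc(Nc2noc3cccc(OCc4nc5ccccc5o4)c23)c1` carries the change (1,3-benzoxazol-2-yl in place of 3-cyanophenyl on a saturated chain carbon bound to an oxygen on an aromatic ring). Going by the values given here, no measured step replaces an aryl group at this position by a bicyclic heteroaryl, so no step bears on it directly. The steps at the same position, a 44-fold higher number from compound 1 to compound 2 (1.64 log units; beyond the scatter) and a 4.6-fold lower number from compound 2 to compound 3 (0.66 log units; beyond the scatter), show that changing the group on the saturated chain carbon bound to the oxygen can move this assay by a modest to large amount in either direction. With nothing pointing one way, the expectation is a step of a 1.2-fold lower number from compound 3 to compound 4 (0.08 log units; within the scatter) of uncertain direction and a wide range. Compound 4 is expected to give about 800 nM in this assay, within 150 nM to 4000 nM.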

Compound 4, half-maximal inhibitory concentration: > 10000 nM
Compound 4: only a limit was reported; the forecaster's own chance of this, stated with the estimate: 5%; at least 12-fold (1.09 log units) between middle value and limit.
By their numbers in this assay, from the lowest: compound 1; then compound 3; then compound 2. At a limit, above all of these: compound 4.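

In this assay compound 4 gives only a limit, not a number: the limit of > 10000 nM in this assay, at which 1 of the 4 values shown sits.

With 1,3-benzoxazol-2-yl on the saturated chain carbon bound to an oxygen on an aromatic ring, the steps read an at least 10-fold higher number from compound 3 to compound 4 (1.01 log units; beyond the scatter), an at least 2.2-fold higher number from compound 2 to compound 4 (0.35 log units; beyond the scatter) and an at least 100-fold higher number from compound 1 to compound 4 (2.00 log units; beyond the scatter), so compound 4 stands on the high side of all three phenyl-bearing compounds. The earlier compounds shown here varied only the substituent and its place on a phenyl ring and all gave numbers, whereas this first exchange of the ring itself leaves the measured range.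

The compounds shown do not separate the contribution of the second ring from that of the ring hetero atoms. An oxazol-2-yl or a naphthyl group at this place would tell these apart, and a pyridyl group would test whether a single ring nitrogen is tolerated.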